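Fluoro for methyl on the pendant phenyl ring

This account rests on a few compounds, and the source may have more. Where it says the series, first, only, none or still open, it means among the compounds named here.

Two compounds of the series have numbers in a functional assay on MCF7 cells (Homo sapiens) for inhibition, read by sulforhodamine B assay, with a stated time of 72 h; a lower number here means a stronger inhibitor, a higher number a weaker inhibitor. Compound 1, `Cc1ccc(C2=Nn3c(nnc3C(C)c3ccc(CC(C)C)cc3)SC2)cc1`, gives 6300 nM and stands lowest of the two. For the measured compounds named here, compound 2, `COc1ccc2cc(C(C)c3nnc4n3N=C(c3ccc([N+](=O)[O-])cc3)CS4)ccc2c1`, gives 18800 nM, a gap beyond the usual scatter, though the two differ in several places and no single step between them is recorded. Compound 3, `CC(C)Cc1ccc(C(C)c2nnc3n2N=C(c2ccc(F)cc2)CS3)cc1`, is not yet measured. It differs from compound 1 in one place: fluoro in place of methyl on an aromatic carbon. Going by the values given here, no measured pair isolates this change, so nothing shows its direction. The exchange is small by count, and the expected step is a 1.1-fold lower number from compound 1 to compound 3 (0.06 log units; within the scatter), which means none beyond the scatter in either direction. Compound 3 is accordingly expected to give 5500 nM in this assay, with a range from 2000 nM to 15000 nM.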

Compound 3, half-maximal inhibitory concentration: 8900 nM
Beside the measured number, compound 3's estimate is 1.6-fold (0.21 log units) below it; low and high end bracket the measured number.
By their numbers in this assay, from the lowest: compounds 1 and 3 (each within the scatter of the next); then compound 2.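

In this assay, for the compounds shown here, the exchange of 4-methylphenyl to 4-fluorophenyl comes with a 1.4-fold higher number from compound 1 to compound 3 (0.15 log units; within the scatter), and this is the first pair to isolate a single change at this position. On the aromatic carbon para to a large group, methyl and fluoro cannot be told apart by this read-out, at least in this one pair, so the position tolerates this exchange without a step beyond the scatter. Nothing available bears on why the number holds across the exchange.

Going by these compounds, whether an amine, a carboxylic acid or a longer chain such as butyl at the same place would move the number beyond the scatter remains open. Also open, on these data alone, is whether the methyl-to-fluoro exchange reads the same when the rest of the shared core carries other groups.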